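Working notes: dimethylamino in place of methoxy

The source may report more compounds than this note shows. Statements on the series, on what has been measured and on what is new or still open speak of the compounds shown alone.

Measured in a functional assay on HCT-116 cells (Homo sapiens) for antiproliferative activity, read by resazurin assay, with a stated time of 5 days; a lower number here means a stronger inhibitor, a higher number a weaker inhibitor:
- compound 1 `Cc1ncoc1C(=O)NCc1ccc2cc(C(=O)NO)sc2c1F`: 210 nM
- compound 2 `COc1ccc(C(=O)NCc2ccc3cc(C(=O)NO)sc3c2F)cc1`: 50 nM

Compound 2 holds the lower of the two numbers in this assay. Compound 3 `CN(C)c1ccc(C(=O)NCc2ccc3cc(C(=O)NO)sc3c2F)cc1` carries dimethylamino in place of methoxy on an aromatic carbon, para to a large group: dimethylamino in place of methoxy on an aromatic carbon. Among the compounds with values here, the only measured step nearby is a 4.2-fold lower number from compound 1 to compound 2 (0.62 log units; beyond the scatter), a modest one that installed the 4-methoxyphenyl. Within the data shown here, no measured step tests a replacement of the methoxy itself, so no step beyond the scatter is expected in this assay, and no direction is favoured. The expected step is a 1.1-fold lower number from compound 2 to compound 3 (0.05 log units; within the scatter). The estimate for compound 3 is 45 nM, with an expected range of 18 nM to 120 nM.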

Compound 3, half-maximal inhibitory concentration: 60 nM
Compound 3: middle estimate off by 1.3-fold (0.12 log units), on the low side; the range from low to high includes it.
By their numbers in this assay, from the lowest: compounds 2 and 3 (each within the scatter of the next); then compound 1.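

At this position, para to a large group, the methoxy itself is now tested: this assay gives a 1.2-fold higher number from compound 2 to compound 3 (0.08 log units; within the scatter) and so does not separate dimethylamino from methoxy. The 4-(dimethylamino)phenyl also keeps the advantage over 4-methyl-1,3-oxazol-5-yl, with a 3.5-fold lower number from compound 1 to compound 3 (0.54 log units; beyond the scatter) here, so that advantage is not confined to the 4-methoxyphenyl. No supporting data bear on this result.

Open, from the compounds shown here alone, is whether a carboxylic acid, a primary amine or a longer alkoxy chain on the same aromatic carbon would hold this level of activity.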